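Carboxy for Hydroxymethyl on a Triazole Hydroxamate Core

This account rests on a few compounds, and the source may have more. Where it says the series, first, only, none or still open, it means among the compounds named here.

Of the compounds shown here, three have been measured in an assay on Sf9 cells for inhibition of histone deacetylase 11 (Homo sapiens), read by fluorescence, tested at 0.5 uM; on this read-out higher numbers stand for more inhibition at the one concentration tested (going by the name of the read-out) and lower numbers for less inhibition. Compound 1 `O=C(/C=C/c1cn([C@H]2C[C@@H](C(=O)O)N(CCCc3ccccc3)C2)nn1)NO` gives 29%. Compound 2 `O=C(NO)c1ccc(-c2cn([C@@H]3C[C@H](C(=O)O)N(CCCc4ccccc4)C3)nn2)cc1` gives only the limit of the assay, < 10%. Compound 3 `O=C(NO)c1ccc(-c2cn([C@H]3C[C@@H](CO)N(CCCc4ccccc4)C3)nn2)cc1` likewise reaches only the limit of the assay, < 10%. Two of the three results therefore sit at that limit (the limit of < 10% in this assay, at which 2 of the 3 values shown sit), and compound 3 stands among them, with no number of its own to mark it off from compound 2.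

Compound 4 `O=C(NO)c1ccc(-c2cn([C@H]3C[C@@H](C(=O)O)N(CCCc4ccccc4)C3)nn2)cc1` has not been measured. It differs from compound 3 by carboxy in place of hydroxymethyl on a saturated ring carbon. Among the measured compounds shown here, since no step between measured compounds is known for this change, the size of its effect is open. Compound 1 carries the same carboxy group and gives a modest number, while compound 2 also carries a carboxy group and stays at the limit. Compound 4 is therefore expected to give about 12%, within a range from 2% to 30%. The step this estimate implies, a number at least 2 percentage points higher from compound 3 to compound 4 (that floor lies within the scatter), is expected to lie within the usual scatter, with a real chance that only a limit is reported again.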

Compound 4, a percentage reported as inhibition, at one concentration (the size of the read-out at that concentration, not a potency): 14%
Compound 4: the middle estimate sits 2 percentage points below what was measured; low and high end bracket the measured number.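

In this assay, carboxy on this saturated ring carbon gives compound 4 a number of its own, where hydroxymethyl in compound 3 gave only a limit, yet the change reads as a number at least 4 percentage points higher from compound 3 to compound 4 (that floor lies within the scatter), so no real gain from the swap is shown. The mirror-image pair reads the same way, as a number at least 4 percentage points higher from compound 2 to compound 4 (that floor lies within the scatter), and this step speaks to configuration alone, for one reason: the fact that compounds 2 and 4 differ only in the configuration as drawn. Among the compounds shown here, with 4-(hydroxycarbamoyl)phenyl in place of 2-(hydroxycarbamoyl)ethenyl on an aromatic carbon, the record shows a number 15 percentage points lower from compound 1 to compound 4 (beyond the scatter), the only one of these steps beyond the usual scatter.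

As far as these compounds go, compounds 2 and 3 are reported only as limits, so the true size of both steps that start from them stays open: the limit of < 10% in this assay, at which 2 of the 4 values shown sit. From the compounds shown here alone, whether an amine or an amide on this saturated ring carbon would give a higher number than carboxy also remains open.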